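The source may hold more compounds than are shown below. What is called first, only, known or untested is meant among the compounds shown, and "the series" means these compounds.

Measured in a functional assay on HCT-116 cells (Homo sapiens) for antiproliferative activity, read by MTT assay, with a stated time of 48 h; a lower number here means a stronger inhibitor, a higher number a weaker inhibitor:

- compound 1 `Cc1c(C(=O)NCCCN(C)C)oc2ccc(N(Cc3ccc(Br)cc3)S(=O)(=O)c3ccc(Br)cc3)cc12`: 3730 nM
- compound 2 `Cc1c(C(=O)OCCCN(C)C)oc2ccc(N(Cc3ccc(Br)cc3)S(=O)(=O)c3ccc(Br)cc3)cc12`: 7050 nM
- compound 3 `Cc1c(C(=O)NCCS(C)(=O)=O)oc2ccc(N(Cc3ccc(Br)cc3)S(=O)(=O)c3ccc(Br)cc3)cc12`: > 40000 nM (a limit of the assay, not a number)

Compound 3 stands at the limit of > 40000 nM in this assay, at which 1 of the 3 values shown sits. Its true value is therefore unknown, and it offers only a limit as a starting point.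

The next compound is compound 4 `Cc1c(C(=O)NCC(O)CO)oc2ccc(N(Cc3ccc(Br)cc3)S(=O)(=O)c3ccc(Br)cc3)cc12`, an amide of the same core. The change is 1,2-dihydroxyethyl in place of (methylsulfonyl)methyl on a saturated chain carbon bound to an amide-type nitrogen: 1,2-dihydroxyethyl replaces (methylsulfonyl)methyl on a saturated chain carbon bound to an amide-type nitrogen.

Going by the values given here, no measured step makes this exact swap, so the evidence is indirect. Two steps remove the dimethylamino end of the chain: an at least 10-fold higher number from compound 1 to compound 3 (1.03 log units; beyond the scatter), and an at least 5.6-fold higher number from compound 2 to compound 3 (0.75 log units; beyond the scatter). Both lie beyond the scatter. By contrast, a 1.9-fold higher number from compound 1 to compound 2 (0.28 log units; within the scatter) shows that exchanging the amide for an ester made no clear difference. Compound 4, like compound 3, has no dimethylamino group, so it is expected to stay with compound 3 at the weak end of the scale rather than approach compound 1 or compound 2.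

No step beyond the scatter is expected in this assay, and the expected step is an at least 1.1-fold lower number from compound 3 to compound 4 (0.05 log units; that floor lies within the scatter). The assay may again report only a limit. The estimate for compound 4 is 35000 nM, with an expected range from 12000 nM to 80000 nM.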

Compound 4, half-maximal inhibitory concentration: 11500 nM
Beside the measured number, compound 4's estimate is 3.0-fold (0.48 log units) above it; the whole stated range lies above it.
By their numbers in this assay, from the lowest: compounds 1, 2 and 4 (each within the scatter of the next, the first and the last beyond it). At a limit, above all of these: compound 3.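

In this assay compound 3 gives no number, only a limit: the limit of > 40000 nM in this assay, at which 1 of the 4 values shown sits. Exchanging its 2-(methylsulfonyl)ethyl for 2,3-dihydroxypropyl on the amide gives an at least 3.4-fold lower number from compound 3 to compound 4 (0.54 log units; beyond the scatter), which shows what compounds 1 to 3 could not: a chain without a dimethylamino group can still give a measurable value in this series, so the loss seen in compound 3 does not extend to every such chain. The dimethylamino amide keeps a modest edge, with a 3.1-fold higher number from compound 1 to compound 4 (0.49 log units; beyond the scatter), while the comparison with the ester gives a 1.6-fold higher number from compound 2 to compound 4 (0.21 log units; within the scatter), so compound 4 cannot be told apart from compound 2 in this assay even though only compound 2 carries the dimethylamino end.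

The compounds shown leave open whether the gain depends on both hydroxyl groups of the 2,3-dihydroxypropyl chain, or whether a chain ending in a single hydroxyl, a carboxylic acid or a primary amine would do as well. They also leave open whether the order seen here in HCT-116 cells would hold in other cell lines, and whether a longer chain carrying the dimethylamino group would widen the edge of compound 1.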